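The compounds below may be only part of what the source reports. "The series", "measured", "known", "first", "only" and "open" are said of these compounds alone.

Compound 2 `COc1cc(-c2cc(/C=C/C(=O)c3ccc(N)cc3)[nH]n2)cc(OC)c1OC` gives 105% in a functional assay on OVCAR-4 cells (Homo sapiens) for cytotoxicity, read by sulforhodamine B assay, with a stated time of 48 h, tested at 0.1 uM (on this read-out higher numbers stand for a weaker effect at the one concentration tested and lower numbers for a stronger effect), level at the digits shown with compound 1 `COc1ccc(-c2cc(/C=C/C(=O)c3ccc(N)cc3)[nH]n2)cc1`, which gives 105%; together these two stand highest of the three numbers. Going by the values given here, compound 3 `COc1ccc(C(=O)/C=C/c2cc(-c3cc(OC)c(OC)c(OC)c3)n[nH]2)cc1` gives 94%, and the step of a number 11 percentage points lower from compound 2 to compound 3 (beyond the scatter) is the only measured change of a single group in this set. Compound 4 `COc1ccc(-c2cc(/C=C/C(=O)c3ccc(N)cc3)[nH]n2)cc1OC` differs from compound 2 by hydrogen in place of methoxy on an aromatic carbon. Among the compounds with values here, no measured step removes a methoxy for hydrogen, so the modest step from compound 2 to compound 3 offers only a loose guide, and all three measured numbers sit close together. Compound 4 is therefore expected to show in this assay a step of a number 2 percentage points lower from compound 2 to compound 4 (within the scatter) that stays within the scatter, with an estimated value of 103%, ranging from 92% to 112%.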

Compound 4, a percentage reported as activity, at one concentration (the size of the read-out at that concentration, not a potency): 90%
The estimate for compound 4 lay 13 percentage points above the measured number, and the stated range ends above it.
By their numbers in this assay, from the lowest: compounds 4 and 3 (each within the scatter of the next); then compounds 1 and 2 (each within the scatter of the next).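

In this assay, going by these compounds alone, the earlier compounds showed a step beyond the scatter only for methoxy in place of amino, whereas this result shows that the methoxy pattern on the other aromatic ring also matters. Taking away the methoxy gives a number 15 percentage points lower from compound 2 to compound 4 (beyond the scatter), and adding a methoxy from the other side gives a number 15 percentage points lower from compound 1 to compound 4 (beyond the scatter), so the number does not follow the methoxy count in one direction. Nothing available explains this turn. From the compounds shown here alone, whether a hydroxy group or a chlorine atom in this place would give a similar number stays open.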